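A few compounds are considered here, and "the series" means these few. Any claim that something is new, unique, unknown or untested is made for them only; others in the source may bear on it.

In a functional assay on cells (Platelet, Homo sapiens) for inhibition (on this read-out lower numbers stand for stronger inhibition and higher numbers for weaker inhibition), compound 1 `CCOC(=O)c1ccc(-c2nn(Cc3ccc(F)cc3)c3ccccc23)cc1` gives > 10000 nM, which is a limit of the assay. Compound 2 `CCOC(=O)c1ccc(-c2nn(Cc3ccccc3OC)c3ccccc23)cc1` gives > 10000 nM, also a limit. Compound 3 `O=C(O)c1ccc(-c2nn(Cc3ccccc3)c3ccccc23)cc1` gives > 10000 nM, again a limit and not a number. Compound 3 therefore has no measured potency to start from, and the other two values offer no number either: the limit of > 10000 nM in this assay, at which 3 of the 3 values shown sit.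

The move to compound 4 `CCCOC(=O)c1ccc(-c2nn(Cc3ccccc3)c3ccccc23)cc1` is propyl in place of hydrogen on an oxygen next to a carbonyl group, which turns carboxy into propoxycarbonyl, with propyl in place of hydrogen on an oxygen next to a carbonyl group. Within the data shown here, the only measured step, a step that the two limits leave unreadable from compound 1 to compound 2, concerns a different change and has no readable size, so it offers no guide here. Among the measured compounds shown here, no step of known size or direction is therefore expected in this assay, and compound 4 is expected to remain weak, most likely reported only as a limit. The expected change is a step that the limit leaves unreadable from compound 3 to compound 4. For compound 4 the estimated value is 12000 nM, with an expected range from 3000 nM to 30000 nM.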

Compound 4, half-maximal inhibitory concentration: > 10000 nM
Compound 4: no number, only a limit; the forecaster's own chance of this, stated with the estimate: 75%; the middle value lies beyond the limit too.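

In this assay, among these compounds, compound 3 and compound 4 each give only a limit and not a number, so no step between them can be read. The compounds shown leave open how strongly any of them inhibits, and which changes would affect it: the limit of > 10000 nM in this assay, at which 4 of the 4 values shown sit.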